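Hydroxamic acid stilbenes on gastric cancer cells

This account rests on a few compounds, and the source may have more. Where it says the series, first, only, none or still open, it means among the compounds named here.

Measured so far:
compound 1 `O=C(NO)c1ccc(/C=C/c2ccnc(-c3cc(F)ccc3O)c2)cc1` gives 1920 nM;
compound 2 `O=C(NO)c1ccc(/C=C/c2ccnc(-c3cccc(O)c3)c2)cc1` gives 2100 nM;
compound 3 `O=C(NO)c1ccc(/C=C/c2cccc(-c3cccc(O)c3)c2)cc1` gives 8820 nM.

All three were tested in a functional assay on MGC-803 cells (Homo sapiens) for antiproliferative activity, read by CellTiter-Glo, with a stated time of 72 h; a lower number here means a stronger inhibitor, a higher number a weaker inhibitor. Compound 3 stands highest of the three; its nearest neighbour is compound 2, and the difference between the two cores of compound 2 and compound 3 is not broken down here. From compound 2 to compound 1 the change 5-fluoro-2-hydroxyphenyl in place of 3-hydroxyphenyl on an aromatic carbon made a step of a 1.1-fold lower number from compound 2 to compound 1 (0.04 log units; within the scatter).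

Compound 4 `O=C(NO)c1ccc(/C=C/c2cccc(-c3cc(F)ccc3O)c2)cc1` has not yet been measured. It arises from compound 3 by 5-fluoro-2-hydroxyphenyl in place of 3-hydroxyphenyl on an aromatic carbon. This is the same kind of change as that from compound 2 to compound 1, but not the same: there the place was on an aromatic carbon of a six-membered aromatic ring with 1 nitrogen, next to the ring nitrogen; here it is on an aromatic carbon of a six-membered aromatic ring of carbon only, in both cases meta to a large group.

Because the earlier step was a 1.1-fold lower number from compound 2 to compound 1 (0.04 log units; within the scatter), the step from compound 3 to compound 4 is expected to be small as well, about a 1.1-fold lower number from compound 3 to compound 4 (0.04 log units; within the scatter). Compound 4 is therefore estimated at 8000 nM in this assay, between 3500 nM and 18000 nM.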

Compound 4, half-maximal inhibitory concentration: > 10000 nM
Compound 4 gave a limit, no number (the forecaster's own chance of this, stated with the estimate: 5%); at least 1.2-fold (0.09 log units) between middle value and limit.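

In this assay compound 4 gave > 10000 nM, which is a limit of the assay and not a number. Placing 5-fluoro-2-hydroxyphenyl where 3-hydroxyphenyl stood on the core of compound 3 therefore gives only a floor for the step, an at least 1.1-fold higher number from compound 3 to compound 4 (0.05 log units; that floor lies within the scatter). The change brought no gain beyond the scatter on either core, but this does not show that it carries over unchanged from one core to the other, nor that the two cores respond differently: the same change on two cores in this assay, a 1.1-fold lower number (0.04 log units; within the scatter) from compound 2 to compound 1 and an at least 1.1-fold higher number (0.05 log units; that floor lies within the scatter) from compound 3 to compound 4; the limit leaves it open whether they differ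

As far as these compounds go, the true value of compound 4 remains open, and so does the size of the step on its core. Also open, from the compounds shown here alone, is whether the same comparison would hold with a methoxy group in place of the hydroxyl, with chlorine in place of the fluorine, or with a carboxylic acid in place of the hydroxamic acid.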